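The compounds below may be only part of what the source reports. "The series", "measured", "known", "first", "only" and "open" are said of these compounds alone.

Measured so far in an ADME assay on microsomes from liver (Homo sapiens) for metabolic stability; on this read-out lower numbers stand for slow clearance and higher numbers for fast clearance:
- Compound 1 `CC(=O)N[C@@H]1CCC[C@H](C(=O)Nc2cc(-c3cnn4c3CCCCC4)c(Cl)cn2)C1` gives 39 mL.min-1.g-1 as a number
- Compound 2 `CC(=O)N[C@@H]1CCC[C@H](C(=O)Nc2cc(-c3cnn4c3OCCC4)c(Cl)cn2)C1` gives < 3 mL.min-1.g-1 as a limit of the assay

Compound 2 stands at the limit of < 3 mL.min-1.g-1 in this assay, at which 1 of the 2 values shown sits, and has a limit, not a number.

Compound 3 `CC(=O)N[C@@H]1CCC[C@H](C(=O)Nc2cc(-c3cnc4n3CC(C)(C)C4)c(Cl)cn2)C1` is not yet measured. It differs from compound 2 as follows: a group of 10 heavy atoms (8 carbon, 2 nitrogen; one five-membered non-aromatic ring with 1 hetero atom, one five-membered aromatic ring with 2 hetero atoms) in place of a group of 9 heavy atoms (6 carbon, 2 nitrogen, 1 oxygen; one five-membered aromatic ring with 2 hetero atoms, one six-membered non-aromatic ring with 2 hetero atoms), on an aromatic carbon. The change sits on an aromatic carbon, ortho to a chloro group and opposite the ring nitrogen.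

Within the data shown here, one measured step bears on this, and it is large and beyond the scatter: an at least 13-fold lower number from compound 1 to compound 2 (1.11 log units; beyond the scatter). That step brought in the same group that leaves here, so the present change partly runs it in reverse, although the entering group is not the one lost there. Among the measured compounds shown here, compound 1 at 39 mL.min-1.g-1 is the only measured compound without that group, and it sets the expected upper region.

In this assay an upward step is therefore expected, estimated as an at least 5.0-fold higher number from compound 2 to compound 3 (0.69 log units; beyond the scatter), toward faster clearance. Compound 3 is expected at 15 mL.min-1.g-1 (estimated range 5 mL.min-1.g-1 to 45 mL.min-1.g-1).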

Compound 3, intrinsic clearance in microsomes in the Homo sapiens assay: 63 mL.min-1.g-1
Beside the measured number, compound 3's estimate is 4.2-fold (0.62 log units) below it; the whole stated range lies below it.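

In the Homo sapiens assay, the change shows an at least 21-fold higher number from compound 2 to compound 3 (1.32 log units; beyond the scatter), so the slow clearance of compound 2 does not carry over to this group of carbon and nitrogen atoms on the same aromatic carbon, opposite the ring nitrogen. The comparison with the seven-membered ring group gives a 1.6-fold higher number from compound 1 to compound 3 (0.21 log units; within the scatter), so two groups without oxygen and with different ring sizes sit together at the fast-clearance end, while compound 2, the only one of the three with a ring oxygen, stands apart. In a physicochemical assay for solubility, in phosphate buffer, at pH 7.4 (a lower number here means a less soluble compound, a higher number a more soluble compound), compound 2 gives 110000 nM and compound 3 gives 280000 nM. The same change from compound 2 to compound 3 also separates the two compounds in the physicochemical assay, where it does not lower the number: the measured solubility of compound 2, 110000 nM, and of compound 3, 280000 nM, a 2.5-fold higher number (0.41 log units; beyond the scatter)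

As far as these compounds go, compound 2 carries a limit of the assay, not a number, so the full size of its steps stays open: the limit of < 3 mL.min-1.g-1 in the Homo sapiens assay, at which 1 of the 3 values shown sits. Also open is whether the low clearance goes with the ring oxygen itself, and whether an ether oxygen or a hydroxyl group in the five-membered non-aromatic ring of compound 3 would bring the clearance down while the solubility of compound 3 holds.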